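The source may report more compounds than this note shows. Statements on the series, on what has been measured and on what is new or still open speak of the compounds shown alone.

Measured so far:
Compound 1 `O=[N+]([O-])c1cccc(-c2nn(-c3ccccc3)cc2C(Nc2nc3ccccc3s2)c2c(O)ccc3ccccc23)c1` gives 43900 nM
Compound 2 `Cc1ccc2nc(NC(c3cn(-c4ccccc4)nc3-c3cccc([N+](=O)[O-])c3)c3c(O)ccc4ccccc34)sc2c1` gives 38400 nM
Compound 3 `Cc1cccc(-c2nn(-c3ccccc3)cc2C(Nc2nc3ccccc3s2)c2c(O)ccc3ccccc23)c1` gives 17300 nM

In a functional assay on MCF7 cells (Homo sapiens) for antiproliferative activity, read by MTT assay, with a stated time of 48 h (a higher number here means a weaker inhibitor, a lower number a stronger inhibitor), compound 1 gives 43900 nM and cannot be separated from compound 2 (a 1.1-fold lower number from compound 1 to compound 2 (0.06 log units; within the scatter)), while compound 3 lies modestly lower (a 2.5-fold lower number from compound 1 to compound 3 (0.40 log units; beyond the scatter)). Compound 4 `COc1ccc(-c2nn(-c3ccccc3)cc2C(Nc2nc3ccccc3s2)c2c(O)ccc3ccccc23)cc1` has 4-methoxyphenyl in place of 3-nitrophenyl on an aromatic carbon. Compound 4, like compound 3, has no nitro group, so methyl in place of nitro is the closest guide. The step of methyl in place of hydrogen changes another part of the molecule and offers little here. A modest move to a lower number is therefore expected in this assay, an estimated 2.2-fold lower number from compound 1 to compound 4 (0.34 log units; beyond the scatter) of similar size. Compound 4 is estimated at 20000 nM with an expected range from 8000 nM to 45000 nM.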

Compound 4, half-maximal inhibitory concentration: 17500 nM
The estimate for compound 4 lay 1.1-fold (0.06 log units) above the measured number; the measured number falls inside the stated range.
By their numbers in this assay, from the lowest: compounds 3 and 4 (each within the scatter of the next); then compounds 2 and 1 (each within the scatter of the next).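

In this assay, 4-methoxyphenyl in place of 3-nitrophenyl gives a 2.5-fold lower number from compound 1 to compound 4 (0.40 log units; beyond the scatter), a step of the same size as the earlier change from nitro to methyl at this place. The comparison of the two groups without nitro gives a 1.0-fold higher number from compound 3 to compound 4 (0.00 log units; within the scatter), so 3-methylphenyl and 4-methoxyphenyl cannot be told apart here. Nothing available explains these numbers. As far as these compounds go, it remains open whether a phenyl bearing an amine or a carboxylic acid at this place would match compound 1 or compound 4.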